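This account rests on a few compounds, and the source may have more. Where it says the series, first, only, none or still open, it means among the compounds named here.

Compound 1 `Cc1ccc(Nc2nc(Cl)nc3c2ncn3Cc2ccc(C(=O)Nc3ccccc3N)cc2)cc1` gives 82.5%; compound 2 `Nc1ccccc1NC(=O)c1ccc(Cn2cnc3c(Nc4ccccc4)nc(Cl)nc32)cc1` gives 77.8%; compound 3 `Nc1ccccc1NC(=O)c1ccc(Cn2cnc3c(NCc4ccccc4)nc(Cl)nc32)cc1` gives 61.2%, all in a functional assay on NCI-H460 cells (Homo sapiens) for antiproliferative activity, read by CCK-8 assay, with a stated time of 72 h, tested at 8 uM; on this read-out lower numbers stand for a weaker effect and higher numbers for a stronger effect at the one concentration tested.

Compound 3 stands lowest of the three, with compound 2 above it by a number 16.6 percentage points lower from compound 2 to compound 3 (beyond the scatter) and compound 1 above it by a number 21.3 percentage points lower from compound 1 to compound 3 (beyond the scatter). Compound 4 `Nc1ccccc1NC(=O)c1ccc(Cn2cnc3c(Nc4ccc(-c5ccccn5)cc4)nc(Cl)nc32)cc1` differs from compound 3 in one place: 4-(pyridin-2-yl)phenyl in place of benzyl on a nitrogen on an aromatic ring. Going by the values given here, the steps that bear on this are those where an aryl group on that nitrogen was replaced by benzyl, namely a number 16.6 percentage points lower from compound 2 to compound 3 (beyond the scatter) and a number 21.3 percentage points lower from compound 1 to compound 3 (beyond the scatter); the present change runs the other way, putting an aryl group back in place of benzyl. A rise of similar size is therefore expected, a number 16.8 percentage points higher from compound 3 to compound 4 (beyond the scatter). Compound 4 is estimated at 78%, between 65% and 90%.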

Compound 4, a percentage reported as inhibition, at one concentration (the size of the read-out at that concentration, not a potency): 30.8%
Compound 4: middle estimate off by 47.2 percentage points, on the high side; measured number below the stated range.
By their numbers in this assay, from the lowest: compound 4; then compound 3; then compounds 2 and 1 (each within the scatter of the next).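

In this assay, an aryl group on this nitrogen does not by itself keep the effect: pyridin-2-yl in place of hydrogen gives a number 47 percentage points lower from compound 2 to compound 4 (beyond the scatter) and in place of methyl gives a number 51.7 percentage points lower from compound 1 to compound 4 (beyond the scatter) on the same aromatic carbon. The earlier order of aryl over benzyl therefore fails for this group, with a number 30.4 percentage points lower from compound 3 to compound 4 (beyond the scatter) when 4-(pyridin-2-yl)phenyl replaces benzyl. From the compounds shown here alone, whether a plain phenyl, a methoxy group or an amine in place of pyridin-2-yl would keep the effect stays open. Nothing given here accounts for the fall.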